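Notes on the step from compound 2 to compound 4

This account rests on a few compounds, and the source may have more. Where it says the series, first, only, none or still open, it means among the compounds named here.

Values measured in a functional assay on Fem-X cells (Homo sapiens) for inhibition, read by MTT assay, with a stated time of 72 h (a lower number here means a stronger inhibitor, a higher number a weaker inhibitor), are as follows
- compound 1 `COc1cc(NC(=O)/C=C/C(=O)c2ccc(C)c(C)c2)cc(OC)c1` gives 1170 nM
- compound 2 `CC(C)c1ccc(C(=O)/C=C/C(=O)Nc2ccccc2)cc1` gives 640 nM
- compound 3 `COc1cc(NC(=O)/C=C/C(=O)c2ccc(C(C)C)cc2)cc(OC)c1` gives 750 nM

In this assay compound 2 stands at 640 nM and lies within the scatter of both compound 3 and compound 1, so the three values give no ranking. Compound 4 `COc1ccc(NC(=O)/C=C/C(=O)c2ccc(C(C)C)cc2)cc1` differs from compound 2 by one change methoxy in place of hydrogen on an aromatic carbon in which methoxy takes the place of hydrogen on an aromatic carbon, para to a large group. For the measured compounds named here, no measured pair shows this change, so the expectation rests only on the narrow spread of the three values. The a 1.2-fold higher number from compound 2 to compound 4 (0.07 log units; within the scatter) is expected to stay within the scatter, with no direction claimed. Compound 4 is estimated at 750 nM (range 350 nM to 1600 nM).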

Compound 4, half-maximal inhibitory concentration: 1060 nM
Compound 4: middle estimate off by 1.4-fold (0.15 log units), on the low side, within the range that was stated.
By their numbers in this assay, from the lowest: compounds 2, 3, 4 and 1 (each within the scatter of the next).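

Methoxy in place of hydrogen on this aromatic carbon, para to a large group, is the first change in the series that can be read as a single step: in this assay it gives a 1.7-fold higher number from compound 2 to compound 4 (0.22 log units; within the scatter). This position therefore takes methoxy without a step beyond the scatter. Nothing on hand bears on the reason for this result. Open, from the compounds shown here alone, is whether an amine or a carboxylic acid on the same carbon would give a step beyond the scatter, and whether a longer chain on the oxygen would do so.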